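This account rests on a few compounds, and the source may have more. Where it says the series, first, only, none or still open, it means among the compounds named here.

Measured so far, in a functional assay on SW-620 cells (Homo sapiens) for cytotoxicity, read by MTT assay, with a stated time of 48 h; on this read-out lower numbers stand for stronger inhibition and higher numbers for weaker inhibition:
- compound 1, `CCCCCCCCCCCCCCCCCCNC(=O)[C@@H](NC(=O)c1cc2ccccc2o1)[C@@H](C)O`, which gives only a limit of the assay, not a number: > 200000 nM
- compound 2, `CCCCCCCCCCCCCCCCCCNC(=O)[C@@H](NC(=O)c1nccc2ccccc12)[C@@H](C)O`, which gives 136000 nM

Within the data shown here, compound 2 thus holds the only actual number in this assay; the other value is a limit (the limit of > 200000 nM in this assay, at which 1 of the 2 values shown sits). Among the measured compounds shown here, the one measured step, an at least 1.4-fold lower number from compound 1 to compound 2 (0.16 log units; that floor lies within the scatter), swapped the aromatic group attached to the carbonyl carbon, and its size cannot be told apart from the usual scatter.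

Compound 3, `CCCCCCCCCCCCCCCCCCNC(=O)[C@@H](NC(=O)c1cc2ccccc2[nH]1)[C@@H](C)O`, is the next member of the series. It differs from compound 2 by 1H-indol-2-yl in place of isoquinolin-1-yl on a carbonyl carbon. For the measured compounds named here, this is again a swap of the aromatic group on the same carbonyl carbon, so the step from compound 1 to compound 2 is the only guide, and that step was not beyond the scatter. No step beyond the scatter is therefore expected in this assay for compound 3, in either direction; the step of a 1.1-fold higher number from compound 2 to compound 3 (0.04 log units; within the scatter) is the estimated one. Compound 3 is expected to give about 150000 nM, with a range from 60000 nM to 300000 nM, and a fair chance that only a limit is reported.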

Compound 3, half-maximal inhibitory concentration: 23600 nM
Compound 3: the middle estimate sits 6.4-fold (0.80 log units) above what was measured, and the stated range ends above it.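

In this assay, the aromatic group on this carbonyl carbon turns out to matter, which the earlier swap could not show: 1H-indol-2-yl in place of isoquinolin-1-yl gives a 5.8-fold lower number from compound 2 to compound 3 (0.76 log units; beyond the scatter). The same group in place of 1-benzofuran-2-yl gives an at least 8.4-fold lower number from compound 1 to compound 3 (0.92 log units; beyond the scatter), so 1H-indol-2-yl stands apart from both of the other groups shown. That second step is only a floor, since compound 1 gives a limit and not a number: the limit of > 200000 nM in this assay, at which 1 of the 3 values shown sits.

The change from compound 2 to compound 3 alters several things at once, as a six-membered ring gives way to a five-membered one and a hydrogen-bond donor enters where the leaving group has none, so these compounds cannot tell which of these features goes with the lower number. On these data alone, a 1-methyl-1H-indol-2-yl group, which keeps the five-membered ring but has a methyl in place of the hydrogen on the ring nitrogen, would help to separate them, and it also remains open whether the step would hold with a shorter chain on the amide nitrogen.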